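Prop-1-en-1-yl in place of vinyl on compound 2

The compounds below may be only part of what the source reports. "The series", "measured", "known", "first", "only" and "open" are said of these compounds alone.

Measured compounds:
compound 1, `O=C(Nc1ccc(Cl)cc1)c1cc([N+](=O)[O-])ccc1Cl`: > 25000 nM
compound 2, `C=CC(=O)Nc1cccc(-c2nc3ccccc3s2)c1`: > 25000 nM

Both compounds were tested in an ADME assay on HEK293 cells (Homo sapiens) for inhibition, with a stated time of 72 h; a higher number here means that more compound is needed for the effect, a lower number that less compound is needed. Compound 1 gives only a limit of the assay, > 25000 nM, not a number. Compound 2 likewise gives only a limit, > 25000 nM. Every value shown here sits at the limit of > 25000 nM in this assay, at which 2 of the 2 values shown sit, so compound 2 stands at the edge of what the assay reports. Compound 3 `C/C=C/C(=O)Nc1cccc(-c2nc3ccccc3s2)c1` differs from compound 2 by prop-1-en-1-yl in place of vinyl on a carbonyl carbon. Among the measured compounds shown here, no step between measured compounds sizes this change, so no shift beyond the scatter is expected, and the expected step is a step that the limit leaves unreadable from compound 2 to compound 3. Compound 3 is thus estimated at 30000 nM, with a range from 10000 nM to 100000 nM, most likely again reported as a limit.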

Compound 3, half-maximal effective concentration: > 25000 nM
Compound 3: a limit, no number; the forecaster's own chance of this, stated with the estimate: 80%; the middle value is on the limit's open side.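

The step from compound 2 to compound 3 cannot be read in this assay, where both compounds give only a limit: the limit of > 25000 nM in this assay, at which 3 of the 3 values shown sit. From the compounds shown here alone, whether prop-1-en-1-yl in place of vinyl on a carbonyl carbon shifts the half-maximal effective concentration at all remains open.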